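Cytotoxicity of compound 3: an expectation

A few compounds are considered here, and "the series" means these few. Any claim that something is new, unique, unknown or untested is made for them only; others in the source may bear on it.

Compound 1 `CC(C)(Oc1ccc(Cl)cc1)C(=O)OCCCOC(=O)CCCCC1CCSS1` gives > 800000 nM (a limit of the assay)
Compound 2 `CC(C)(Oc1ccc(Cl)cc1)C(=O)Oc1ccc(C(N)=S)cc1` gives 797000 nM (a number)

Among the compounds with values here, in an ADME assay on H9c2 cells (Rattus norvegicus) for cytotoxicity, read by MTT assay, with a stated time of 48 h (on this read-out lower numbers stand for stronger inhibition and higher numbers for weaker inhibition), compound 2 gives the only actual number so far. The value of compound 1 is a limit of the assay and not a number.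

Compound 3 `CC(C)(Oc1ccc(Cl)cc1)C(=O)Oc1ccc(-c2cc(=S)ss2)cc1` has not yet been measured. It differs from compound 2 in one place (a group of 6 heavy atoms (3 carbon, 3 sulfur; one five-membered aromatic ring with 2 hetero atoms) in place of a group of 3 heavy atoms (1 carbon, 1 nitrogen, 1 sulfur; no ring), on an aromatic carbon), on an aromatic carbon of a six-membered aromatic ring of carbon only, para to a large group. A group with one five-membered aromatic ring with 2 hetero atoms enters, and a group with no ring leaves.

No measured step sizes this change, so the expectation rests on compound 2 at 797000 nM alone. The expected step is a 3.2-fold lower number from compound 2 to compound 3 (0.50 log units; beyond the scatter) (towards stronger inhibition in this assay). Compound 3 is estimated at 250000 nM (expected range 60000 nM to 700000 nM).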

Compound 3, half-maximal inhibitory concentration: 675000 nM
Compound 3: middle estimate off by 2.7-fold (0.43 log units), on the low side; measured number inside the range.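

In this assay, putting the five-membered aromatic ring with 2 hetero atoms in place of the ringless group on the aromatic carbon gives a 1.2-fold lower number from compound 2 to compound 3 (0.07 log units; within the scatter). This shows that at this position, para to a large group, the larger ring-bearing group and the smaller ringless group cannot be told apart in this read-out, which compound 2 alone could not show. Both numbers lie near the upper end of what this assay reports: the limit of > 800000 nM in this assay, at which 1 of the 3 values shown sits.

The compounds shown leave open whether any group at this carbon, such as an amine or a carboxylic acid, would move the number beyond the scatter. They also leave open whether a change elsewhere in the shared core, such as an amide in place of the ester, would do so.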